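One Stereocentre Redrawn in a Series at Its Limits

A few compounds are considered here, and "the series" means these few. Any claim that something is new, unique, unknown or untested is made for them only; others in the source may bear on it.

Measured so far in a physicochemical assay for solubility (on this read-out lower numbers stand for lower solubility and higher numbers for higher solubility), each value a limit and not a number:
compound 1 `CNC(=O)c1cc(C(=O)N[C@H]2[C@@H]3C[C@H](O)C[C@@H]32)cc2c1OC[C@@]2(C)c1ccccc1` gives >= 151 ug/mL as a limit
compound 2 `CNC(=O)c1cc(C(N)=O)cc2c1OC[C@H]2c1ccccc1` gives >= 144 ug/mL as a limit
compound 3 `CNC(=O)c1cc(C(=O)NC2CC2)cc2c1OC[C@H]2c1ccccc1` gives >= 190 ug/mL as a limit
Not yet measured: compound 4 `CNC(=O)c1cc(C(=O)N[C@H]2[C@@H]3C[C@@H](O)C[C@@H]32)cc2c1OC[C@@]2(C)c1ccccc1` in the same assay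

For compound 1 the reading >= 151 ug/mL is a limit. The other two measured compounds also hold only limits, so no order among the three can be read.

The change to compound 4 is the two compounds have the same atoms and bonds and differ only in configuration as drawn: 1 of 5 stereo elements differ; a stereocentre at a saturated ring carbon is drawn S in compound 1 and R in compound 4 and no group leaves or enters. In words, a stereocentre at a saturated ring carbon is drawn S in compound 1 and R in compound 4.

Going by the values given here, the only measured step is a step that the two limits leave unreadable from compound 2 to compound 3 and it concerns cyclopropyl in place of hydrogen on an amide-type nitrogen, with no change of configuration. It has no readable size and does not speak to the present change.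

The expectation therefore rests on compound 1 at >= 151 ug/mL and on the absence of any measured step of this kind. The expected step is a step that the limit leaves unreadable from compound 1 to compound 4 in this assay, with no step beyond the usual scatter and no direction favoured. For compound 4 the estimate is 165 ug/mL with an expected range from 95 ug/mL to 260 ug/mL and a limit is also expected to be likely.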

Compound 4, solubility: >= 209 ug/mL
Compound 4 ended at the assay's limit; the forecaster's own chance of this, stated with the estimate: 75%; at least 1.2-fold (0.10 log units) between middle value and limit.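

In this assay compound 1 and compound 4 both hold only limits, not numbers, so no new step can be read between these two compounds. The compounds shown leave open whether the stereocentre at a saturated ring carbon, drawn S in compound 1 and R in compound 4, moves this read-out at all, and in which direction.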